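The source may report more compounds than this note shows. Statements on the series, on what has been measured and on what is new or still open speak of the compounds shown alone.

Compound 1 `COc1ccc(NC(=O)NC2CC(C)(C)Oc3ccc(Br)cc32)cc1`: in a functional assay (aorta) with Rattus norvegicus as the target (a higher number here means that more compound is needed for the effect, a lower number that less compound is needed), compound 1 gives > 10000 nM, which is a limit of the assay and not a number.
Compound 2 `Cc1ccccc1NC(=O)NC1CC(C)(C)Oc2ccc(Br)cc21`: in this assay compound 2 gives > 30000 nM, again a limit.
Compound 3 `Cc1ccc(NC(=O)NC2CC(C)(C)Oc3ccc(F)cc32)cc1`: in this assay compound 3 gives > 30000 nM, also a limit.

Compound 3 therefore stands at a limit, as do the other two measured compounds: two values sit at the limit of > 30000 nM in this assay, at which 2 of the 3 values shown sit, and one at the limit of > 10000 nM in this assay, at which 1 of the 3 values shown sits. Going by the values given here, no number for compound 3 is known, only that it needs more compound than the assay can read.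

Compound 4 `Cc1ccc(NC(=O)NC2CC(C)(C)Oc3ccc(Br)cc32)cc1` arises from compound 3 by bromo in place of fluoro on an aromatic carbon. Among the compounds with values here, the only measured step, a step that the two limits leave unreadable from compound 1 to compound 2, exchanges the aryl group on the urea nitrogen and does not touch this halogen, and both limits leave its size unreadable. Compounds 1 and 2, which already carry bromo at this place, both sit at limits, and compound 3, with fluoro, sits at a limit too.

Compound 4 is therefore expected to remain at a limit, estimated at 30000 nM, between 10000 nM and 100000 nM. The expected step of a number no higher from compound 3 to compound 4 (the limit leaves the size open) is no change beyond the scatter.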

Compound 4, half-maximal effective concentration: > 30000 nM
Compound 4 gave a limit, no number; the forecaster's own chance of this, stated with the estimate: 85%; the middle value sits exactly at the limit.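

Compound 4 sits at a limit, as do compound 1, compound 2 and compound 3, so no step among these compounds can be read. The compounds shown leave open what concentration of any of them gives the half-maximal effect in this assay, and whether bromo and fluoro differ there.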